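This account rests on a few compounds, and the source may have more. Where it says the series, first, only, none or still open, it means among the compounds named here.

Measured so far:
- compound 1, `Cc1ccc(Cn2cc(COc3ccc4c(=O)ccoc4c3)nn2)cc1`: 10400 nM
- compound 2, `O=c1ccoc2cc(OCc3cn(Cc4cccc([N+](=O)[O-])c4)nn3)ccc12`: > 100000 nM
- compound 3, `C#CCOc1ccc2c(=O)ccoc2c1`: > 100000 nM

In a functional assay on SW480 cells (Homo sapiens) for cytotoxicity, read by MTT assay, with a stated time of 48 h (a lower number here means a stronger inhibitor, a higher number a weaker inhibitor), compound 1 gives 10400 nM. For compound 2 the assay reports only a limit, > 100000 nM. For compound 3 the assay likewise reports only a limit, > 100000 nM. Among the measured compounds shown here, compound 2 thus sits at the limit of > 100000 nM in this assay, at which 2 of the 3 values shown sit, and the one measured step reaching it is an at least 9.6-fold higher number from compound 1 to compound 2 (0.98 log units; beyond the scatter), a move from a number to a limit.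

Compound 4, `COc1ccc(Cn2cc(COc3ccc4c(=O)ccoc4c3)nn2)cc1`, is not yet measured. It differs from compound 2 in one place: 4-methoxyphenyl in place of 3-nitrophenyl on a saturated chain carbon bound to an aromatic nitrogen. For the measured compounds named here, compound 4 thereby carries a substituent of the same kind as compound 1, which gave the only finite number in the set. The step that bears on the change is an at least 9.6-fold higher number from compound 1 to compound 2 (0.98 log units; beyond the scatter), run here in reverse: the 3-nitrophenyl that took compound 2 to the limit leaves again. A downward step, back toward the number of compound 1, is therefore expected, namely an at least 6.6-fold lower number from compound 2 to compound 4 (0.82 log units; beyond the scatter). Compound 4 is expected at 15000 nM, with a range from 5000 nM to 60000 nM.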

Compound 4, half-maximal inhibitory concentration: 20400 nM
For compound 4 the middle estimate is 1.4-fold (0.13 log units) below the measured one, within the range that was stated.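

In this assay, among the compounds shown here, the step of an at least 4.9-fold lower number from compound 2 to compound 4 (0.69 log units; beyond the scatter) shows that this position, on a saturated chain carbon bound to an aromatic nitrogen, regains a finite number with a second group, 4-methoxyphenyl, so compound 1 is no longer the only finite value in the set. The step of a 2.0-fold higher number from compound 1 to compound 4 (0.29 log units; within the scatter) shows that methoxy in place of methyl on an aromatic carbon cannot be told apart in this read-out. Compound 2 remains a limit, so its step gives a bound and not a full size: the limit of > 100000 nM in this assay, at which 2 of the 4 values shown sit.

Open, on these data alone, is whether the loss at compound 2 follows the nitro group itself or its place on the ring. Also open, as far as these compounds go, is how an amine or a carboxylic acid on that ring, or a longer chain at the same position, would read.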